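Ester for amide at the carbonyl of compound 1

A few compounds are considered here, and "the series" means these few. Any claim that something is new, unique, unknown or untested is made for them only; others in the source may bear on it.

Among the compounds with values here, compound 1 `CCN(CC)CCNC(=O)c1ccc(C(CC)(CC)c2ccc(OCC(=O)C(C)(C)C)c(C)c2)n1CC` gives 91 nM in an assay on HL-60 cells for agonist activity at vitamin D3 receptor (Homo sapiens), read by microscopy, with a stated time of 96 h (a lower number here means that less compound is needed, a higher number that more compound is needed for the effect), and stands highest of the two numbers measured so far. Compound 2 `CC[C@@H](C)[C@H](NC(=O)c1ccc(C(CC)(CC)c2ccc(OCC(O)C(C)(C)C)c(C)c2)n1CC)C(=O)OC` gives 26 nM in this assay, and the gap between these two compounds lies beyond the scatter. Compound 3 `CCOC(=O)c1ccc(OC(=O)c2ccc(C(CC)(CC)c3ccc(OCC(=O)C(C)(C)C)c(C)c3)n2CC)cc1` is not yet measured; it differs from compound 1 in one place: 4-(ethoxycarbonyl)phenoxy in place of (2-(diethylamino)ethyl)amino on a carbonyl carbon. Within the data shown here, no step between measured compounds covers such a change, so the expected step of a 2.2-fold higher number from compound 1 to compound 3 (0.34 log units; beyond the scatter) is a modest shift toward a higher number, only just beyond the scatter. For compound 3 the estimated value is 200 nM, with a range from 50 nM to 900 nM.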

Compound 3, half-maximal effective concentration: 45600 nM
The estimate for compound 3 lay 230-fold (2.36 log units) below the measured number, and the stated range ends below it.
By their numbers in this assay, from the lowest: compound 2; then compound 1; then compound 3.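

On the carbonyl carbon whose other neighbour is aromatic carbon, 4-(ethoxycarbonyl)phenoxy in place of (2-(diethylamino)ethyl)amino gives a 500-fold higher number from compound 1 to compound 3 (2.70 log units; beyond the scatter) in this assay. Within the data shown here, this is the first step read at this position, and its size shows that activity depends strongly on the group carried there. No evidence on hand bears on the reason for this step.

On these data alone, the change replaces the amide link and the side chain together, so the share of each in the step stays open. An amide bearing a 4-(ethoxycarbonyl)phenyl group, or a plain ethyl ester, would separate the two.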